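A second fluoro on the core of compound 3

A few compounds are considered here, and "the series" means these few. Any claim that something is new, unique, unknown or untested is made for them only; others in the source may bear on it.

In a functional assay on the whole organism with Mus musculus as the target, in the rotarod test (a lower number here means that less compound is needed, a higher number that more compound is needed for the effect), compound 3 (`NC(=O)/C=C1\CCc2cc(F)ccc21`) gives > 100 mg/kg as a limit and not as a number. Compound 4 (`NC(=O)/C=C1\CCc2c1ccc(F)c2F`) carries fluoro in place of hydrogen on an aromatic carbon, ortho to a fluoro group and ortho to a fused ring. The closest measured comparison is compound 1 (`NC(=O)/C=C1\CCc2cc(F)c(F)cc21`), which also carries a second fluoro, at another place on the shared core, and gives 82 mg/kg in this test. Taking that fluoro away gives an at least 1.2-fold higher number from compound 1 to compound 3 (0.08 log units; that floor lies within the scatter) and so fixes no firm size. Compound 2 (`O=C(/C=C1\CCc2cc(F)ccc21)NC1CC1`) gives 193 mg/kg with cyclopropyl on the amide-type nitrogen, but that change lies elsewhere, and its step is a step that the limit leaves unreadable from compound 2 to compound 3 and bears little on this one. Going by compound 1 at 82 mg/kg, a small move to a lower number is expected. The expected step is an at least 1.1-fold lower number from compound 3 to compound 4 (0.04 log units; that floor lies within the scatter) and may stay within the scatter. For this assay compound 4 is estimated at 90 mg/kg with an expected range of 40 mg/kg to 200 mg/kg on this reading.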

Compound 4, dose for half-maximal effect: 50 mg/kg
Compound 4: the middle estimate sits 1.8-fold (0.26 log units) above what was measured; the measured number falls inside the stated range.
By their numbers in this assay, from the lowest: compounds 4 and 1 (each within the scatter of the next); then compound 2.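

In this assay, fluoro at the place ortho to a fluoro group and ortho to a fused ring gives an at least 2.0-fold lower number from compound 3 to compound 4 (0.30 log units; that floor lies within the scatter). That size is only a floor because compound 3 stands at a limit and not at a number: the limit of > 100 mg/kg in this assay, at which 1 of the 4 values shown sits.

Compound 1, with its second fluoro at another place on the shared core, gives 82 mg/kg and compound 4 gives 50 mg/kg; these two values lie within the scatter of each other, so this test does not separate the two places.

Going by these compounds, the true size of the step from the unfluorinated place stays open, as does what chloro, methoxy or trifluoromethyl would give there. On these data alone, it also stays open whether cyclopropyl on the amide-type nitrogen would change the number on the core of compound 4.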